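Removing the Iodine from a Weak Pancreatic Cell Inhibitor

The source may report more compounds than this note shows. Statements on the series, on what has been measured and on what is new or still open speak of the compounds shown alone.

Compound 1 `O=C1O/C(=C\Cn2cc(C(F)(F)F)c(=O)[nH]c2=O)C(OCc2ccccc2)=C1OCc1ccccc1` and compound 2 `O=C1O/C(=C\Cn2cc(I)c(=O)[nH]c2=O)C(OCc2ccccc2)=C1OCc1ccccc1` share one core and differ only on one aromatic carbon. In a functional assay on MIA PaCa-2 cells (Homo sapiens) for inhibition (on this read-out lower numbers stand for stronger inhibition and higher numbers for weaker inhibition), compound 1 gives 30000 nM, and in this assay compound 2 gives 80000 nM. The change a 2.7-fold higher number from compound 1 to compound 2 (0.43 log units; beyond the scatter) is modest. Within the data shown here, compound 2 therefore stands with the highest number of the two measured compounds, with compound 1 the only neighbour.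

Compound 3 `O=C1O/C(=C\Cn2ccc(=O)[nH]c2=O)C(OCc2ccccc2)=C1OCc1ccccc1` is the next member of this series. It is hydrogen in place of iodo on an aromatic carbon.

Among the measured compounds shown here, only the step from compound 1 to compound 2 touches the same carbon, and it was modest in size; no measured step removes a group from that carbon altogether. Compound 3 is therefore expected to stay in the same weak range, with a step of a 1.6-fold lower number from compound 2 to compound 3 (0.20 log units; within the scatter) in this assay. For compound 3 an estimate of 50000 nM is given, with a range from 15000 nM to 150000 nM.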

Compound 3, half-maximal inhibitory concentration: 30000 nM
Beside the measured number, compound 3's estimate is 1.7-fold (0.22 log units) above it, within the range that was stated.
By their numbers in this assay, from the lowest: compounds 1 and 3 (each within the scatter of the next); then compound 2.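

Taking the substituent off this aromatic carbon shows, in this assay, that iodo is the only one of the three groups that sets its compound apart: hydrogen in place of iodo gives a 2.7-fold lower number from compound 2 to compound 3 (0.43 log units; beyond the scatter), while hydrogen in place of trifluoromethyl gives no change at the digits printed from compound 1 to compound 3 (within the scatter). Neither group therefore improves on plain hydrogen here, since trifluoromethyl gives no reading apart from hydrogen and iodo gives the higher number. Nothing in the data given explains why iodo stands apart from the other two.

What the compounds shown leave open is whether any group on this carbon can move the number out of this weak range. An amine, a carboxylic acid or a longer chain here could go either way, and three compounds cannot say which.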